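The compounds below may be only part of what the source reports. "The series", "measured", "known", "first", "only" and "open" are said of these compounds alone.

In a toxicity assay on NIH3T3 cells (Mus musculus) for cytotoxicity, read by resazurin assay (a higher number here means that more compound is needed for the effect, a lower number that less compound is needed), compound 3 `COC(=O)c1ccc(NCc2cncn2Cc2ccccc2Br)cc1-c1ccccc1` gives 10000 nM. Compound 2 `COC(=O)c1ccc(NCc2cncn2Cc2ccccc2Cl)cc1-c1ccccc1` gives 10000 nM, and the step of no change at the digits printed from compound 2 to compound 3 (within the scatter) shows that exchanging chloro for bromo left the reading where it was. Compound 1 `COC(=O)c1ccc(NCc2cncn2Cc2ccccc2)cc1-c1ccccc1` gives > 1000 nM, which is a limit of this assay rather than a number (the limit of > 1000 nM in this assay, at which 1 of the 3 values shown sits). The steps a step that the limit leaves unreadable from compound 1 to compound 2 and a step that the limit leaves unreadable from compound 1 to compound 3 therefore cannot be sized. Compound 4 `COC(=O)c1ccc(NCc2cncn2Cc2cccc(C#N)c2)cc1-c1ccccc1` differs from compound 3 by 3-cyanophenyl in place of 2-bromophenyl on a saturated chain carbon bound to an aromatic nitrogen. Of the measured steps only no change at the digits printed from compound 2 to compound 3 (within the scatter) bears on this change, and it was flat, so no movement beyond the scatter is expected; the step of no change at the digits printed from compound 3 to compound 4 (within the scatter) is the estimate. Compound 4 is expected to give 10000 nM, within a range of 3000 nM to 30000 nM.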

Compound 4, half-maximal effective concentration: > 10000 nM
Compound 4 was reported as a limit; the forecaster's own chance of this, stated with the estimate: 40%; the middle value lies on the limit itself.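

The step of a number no lower from compound 3 to compound 4 (the limit leaves the size open) comes with 3-cyanophenyl in place of 2-bromophenyl on a saturated chain carbon bound to an aromatic nitrogen, and the step of a number no lower from compound 2 to compound 4 (the limit leaves the size open) comes with 3-cyanophenyl in place of 2-chlorophenyl. Among the earlier compounds with readable values only the halogen changed, whereas here a nitrile stands in its stead and the number in this assay still comes out no lower. The value of compound 4 is a limit and not a number: the limit of > 10000 nM in this assay, at which 1 of the 4 values shown sits.

On these data alone, how far the number lies beyond that limit stays open, and the steps from compound 1 cannot be read. As far as these compounds go, whether an amine or a carboxylic acid on this benzyl ring would bring the number down also stays open.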